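Benzoyloxy for 1H-imidazol-1-yl on the shared core

A few compounds are considered here, and "the series" means these few. Any claim that something is new, unique, unknown or untested is made for them only; others in the source may bear on it.

- compound 1 (`C=C1CCC2C(C)(CO)[C@H](O)CC[C@@]2(C)[C@@H]1CCn1c(N)nccc1=O`): > 100000 nM as a limit
- compound 2 (`C=C1CCC2[C@](C)(CO)[C@H](O)CC[C@@]2(C)[C@@H]1CCn1ccnc1`): > 50000 nM as a limit
- compound 3 (`C=C1CCC2[C@](C)(CO)[C@H](O)CC[C@@]2(C)[C@@H]1CCOc1cccc2ccccc12`): 44700 nM as a number

All three values come from a functional assay on RAW264.7 cells (Mus musculus) for inhibition, read by Griess assay, with stated times of 3 h and 24 h (a higher number here means a weaker inhibitor, a lower number a stronger inhibitor), and only compound 3 gives a number. Compound 2 stands at the limit of > 50000 nM in this assay, at which 1 of the 3 values shown sits, and so has a limit, not a number. Within the data shown here, no measured step links any pair in this set, which leaves the values alone as a guide.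

Compound 4 (`C=C1CCC2[C@](C)(CO)[C@H](O)CC[C@@]2(C)[C@@H]1CCOC(=O)c1ccccc1`) carries benzoyloxy in place of 1H-imidazol-1-yl on a saturated chain carbon, two bonds along the chain from a saturated ring carbon. The entering group brings one six-membered aromatic ring of carbon only. Compound 3 also holds aromatic rings of carbon only and reads 44700 nM in this assay and this is the nearest reference for the expectation. The expected at least 1.2-fold lower number from compound 2 to compound 4 (0.09 log units; that floor lies within the scatter) is small, toward a stronger inhibitor, and may not pass beyond the scatter. A further limit instead of a number remains a real possibility. For compound 4 the estimated value is 40000 nM with an expected range from 15000 nM to 100000 nM for the half-maximal inhibitory concentration.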

Compound 4, half-maximal inhibitory concentration: > 100000 nM
Compound 4 was reported as a limit; the forecaster's own chance of this, stated with the estimate: 35%; middle value at least 2.5-fold (0.39 log units) from the limit.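

In this assay compound 4 gives > 100000 nM, a limit. Among these compounds, compound 2 gives > 50000 nM, also a limit, and no step between these two compounds can be read. The compounds shown leave open whether benzoyloxy or 1H-imidazol-1-yl on the shared core gives the stronger inhibitor, and by how much.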